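The source may report more compounds than this note shows. Statements on the series, on what has been measured and on what is new or still open speak of the compounds shown alone.

Working notes on the series.

Compound 1 `CNc1cc(Nc2cc(C)cc(C)c2)nn2c(C(=O)NCC(C)(C)CO)cnc12` is the starting point of this comparison. Among the compounds with values here, in an ADME assay on microsomes from liver (Homo sapiens) for metabolic stability, read by mass spectrometry, with a stated time of 10 min, tested at 0.5 uM (a lower number here means that less of the compound is left, a higher number that more of the compound is left), compound 1 gives 20%, the lowest of the three numbers so far. Compound 3 `CNc1cc(Nc2ccccc2OC)nn2c(C(=O)NCC(C)(C)CO)cnc12` is the nearest of the measured compounds and gives 85%; compound 2 `CNc1cc(Nc2cc(F)cc(F)c2OC)nn2c(C(=O)NC[C@](C)(O)CO)cnc12`, the furthest, gives 99%. Within the data shown here, the only single-point step measured so far is a number 65 percentage points higher from compound 1 to compound 3 (beyond the scatter), and that step changes the aryl group on the ring nitrogen, not the amide side.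

Compound 4 `CNc1cc(Nc2cc(C)cc(C)c2)nn2c(C(N)=O)cnc12` differs from compound 1 at the amide: hydrogen in place of 2-(hydroxymethyl)-2-methylpropyl on an amide-type nitrogen. Among the measured compounds shown here, no measured step touches this position, so the series offers no direct guide for its size. The aryl group that distinguishes compound 1 from compound 3 and compound 2 is kept unchanged in compound 4, and compound 1 carries the lowest value with it; on that basis the expectation is a number that stays closer to compound 1 than to compound 3, with the possibility of a modest rise.

Compound 4 is therefore estimated at 35% in this assay, with a likely range from 10% to 70%. The expected step for compound 4 is a number 15 percentage points higher from compound 1 to compound 4 (beyond the scatter), which is taken as small and uncertain in direction.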

Compound 4, percent of the compound remaining: 15%
Compound 4: middle estimate off by 20 percentage points, on the high side; measured number inside the range.
By their numbers in this assay, from the lowest: compounds 4 and 1 (each within the scatter of the next); then compound 3; then compound 2.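

In this assay, the amide position now has its first readable step: a number 5 percentage points lower from compound 1 to compound 4 (within the scatter). Within the data shown here, with the 3,5-dimethylphenyl group kept on the shared core, hydrogen in place of 2-(hydroxymethyl)-2-methylpropyl on the amide-type nitrogen therefore gives a number that cannot be told apart from that of the parent, while the one step at the aryl group, a number 65 percentage points higher from compound 1 to compound 3 (beyond the scatter), remains the only large step. No measured evidence accounts for this result, for either the amide or the aryl position.

The compounds shown leave open whether the amide position would stay as silent with the 2-methoxyphenyl group of compound 3 in place, since a reading at a low number with the 3,5-dimethylphenyl group need not carry over to that aryl group. They also leave open what a simple methyl group, a longer alkyl chain, or a chain ending in an amine or a carboxylic acid on the same amide-type nitrogen would give.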